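Methyl to fluoro on the phenoxy ring of a sulfonylurea series

The source may hold more compounds than are shown below. What is called first, only, known or untested is meant among the compounds shown, and "the series" means these compounds.

Measured compounds:
Compound 1 `Cc1ccc(Oc2ccc(C#N)cc2S(=O)(=O)NC(=O)NC(C)(C)C)cc1` — 680 nM
Compound 2 `CCCCCNC(=O)NS(=O)(=O)c1cc(C#N)ccc1Oc1ccc(C)cc1` — 630 nM

Among the measured compounds shown here, in a functional assay on HEK293 cells for antagonist activity at thromboxane A2 receptor (Homo sapiens), read by fluorescence and calcium flux (a higher number here means a weaker inhibitor, a lower number a stronger inhibitor), compound 1 gives 680 nM, the higher of the two numbers recorded; the only neighbour is compound 2, and the step of a 1.1-fold lower number from compound 1 to compound 2 (0.03 log units; within the scatter) lies within the scatter.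

Compound 3 `CC(C)(C)NC(=O)NS(=O)(=O)c1cc(C#N)ccc1Oc1ccc(F)cc1` has not yet been measured. The change from compound 1 is fluoro in place of methyl on an aromatic carbon. For the measured compounds named here, the one measured step, pentyl in place of tert-butyl on the urea nitrogen, concerns the other end of the shared core and does not bear on the phenoxy ring. Going by the values given here, no step in this set tells how an exchange on that ring moves this assay, so the expectation rests on compound 1 alone: no shift beyond the scatter, in either direction.

For compound 3 the estimate is 700 nM (range 250 nM to 2000 nM), an expected step of a 1.0-fold higher number from compound 1 to compound 3 (0.01 log units; within the scatter).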

Compound 3, half-maximal inhibitory concentration: 3890 nM
Compound 3: middle estimate off by 5.6-fold (0.74 log units), on the low side; the measured number lies above the stated range.
By their numbers in this assay, from the lowest: compounds 2 and 1 (each within the scatter of the next); then compound 3.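

The phenoxy ring is not a silent part of the shared core: in this assay, 4-fluorophenoxy in place of 4-methylphenoxy, with the tert-butyl urea held constant, gives a 5.7-fold higher number from compound 1 to compound 3 (0.76 log units; beyond the scatter) and so moves the number beyond the scatter. A change of one heavy atom at this place, para to a large group, is enough for that step, with no change in the counted hydrogen-bond donors, hydrogen-bond acceptors or net charge. No measurement at hand accounts for the step.

Among the compounds shown here, the fluoro exchange is seen only on the tert-butyl urea, so whether it carries over to the pentyl urea of compound 2 stays open. Also open, from the compounds shown here alone, is how chloro, methoxy, ethyl or plain hydrogen at this place would compare with methyl and fluoro.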